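The source may report more compounds than this note shows. Statements on the series, on what has been measured and on what is new or still open speak of the compounds shown alone.

Series notes. Compound 1 `C[C@H]1CC[C@@H]2[C@@H](OC(=O)[C@]23CC(c2ccc(Cl)cc2)N(c2ccccc2)O3)[C@]2(C)C(=O)C=C[C@@]12O` and compound 2 `C[C@H]1CC[C@@H]2[C@@H](OC(=O)[C@]23CC(c2ccc(F)cc2)N(c2ccccc2)O3)[C@]2(C)C(=O)C=C[C@@]12O` share one core; compound 3 `C[C@H]1CC[C@@H]2[C@@H](OC(=O)[C@]23CC(c2cccc(Cl)c2)N(c2ccccc2)O3)[C@]2(C)C(=O)C=C[C@@]12O` has the same atoms as compound 1, joined differently, the difference being (3-chlorophenyl in place of 4-chlorophenyl on a saturated ring carbon). In a physicochemical assay for lipophilicity (on this read-out lower numbers stand for lower lipophilicity and higher numbers for higher lipophilicity), compound 1 gives 3.87, compound 2 gives 3.35 and compound 3 gives 3.87. The change from compound 1 to compound 2 is fluoro in place of chloro on an aromatic carbon, and it produced a number 0.52 log units lower from compound 1 to compound 2 (beyond the scatter). Between compound 1 and compound 3 there is no change at the digits printed from compound 1 to compound 3 (within the scatter), so these two sit together at the top of the three numbers, with compound 2 separated from compound 3 by a number 0.52 log units higher from compound 2 to compound 3 (beyond the scatter).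

Compound 4 `C[C@H]1CC[C@@H]2[C@@H](OC(=O)[C@]23CC(c2cccc(F)c2)N(c2ccccc2)O3)[C@]2(C)C(=O)C=C[C@@]12O` is not yet measured. It differs from compound 3 by fluoro in place of chloro on an aromatic carbon. This is the same kind of change as the one from compound 1 to compound 2, and it occurs twice among the compounds shown, but the two places are not the same word for word: in compound 1 the group sits para to a large group, in compound 3 it sits meta to a large group. Going by the values given here, the expected step from compound 3 to compound 4 rests on the single measured instance, compound 1 to compound 2 with a number 0.52 log units lower from compound 1 to compound 2 (beyond the scatter), and is put at a number 0.52 log units lower from compound 3 to compound 4 (beyond the scatter). In this assay compound 4 is therefore estimated at 3.35, expected to fall between 3.05 and 3.65.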

Compound 4, partition coefficient: 3.35
Compound 4: the middle estimate sits on the measured number at the digits printed; low and high end bracket the measured number.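

In this assay fluoro in place of chloro on an aromatic carbon gives a number 0.52 log units lower from compound 3 to compound 4 (beyond the scatter) in the 3-chlorophenyl setting and a number 0.52 log units lower from compound 1 to compound 2 (beyond the scatter) in the 4-chlorophenyl setting, so across these two pairs the step carries over at the same size at the digits printed. The other comparisons agree with this reading, with no change at the digits printed from compound 2 to compound 4 (within the scatter) between the two fluoro compounds and a number 0.52 log units lower from compound 1 to compound 4 (beyond the scatter) where both the halogen and its placing differ, yet two pairs on one shared core do not show that the step would hold on a different core or at any other place on the ring. No measurement shown gives a reason for the size of the step.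

The compounds shown carry only chloro or fluoro on this ring, so it remains open whether a bromo, a methoxy, a nitrile or an amine in the same places would behave in line with these four compounds. Also open, as far as these compounds go, is whether the chloro to fluoro step keeps its size once a carboxylic acid or a longer chain stands elsewhere on the shared core, and whether any read-out other than this assay follows the same course.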